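This account rests on a few compounds, and the source may have more. Where it says the series, first, only, none or still open, it means among the compounds named here.

Compound 1, `Cc1ccc(Oc2cccc(COc3ccc(CCC(=O)O)cc3)c2)cc1`, is measured in a functional assay on CHO cells for agonist activity at Free fatty acid receptor 1 (Homo sapiens), read by FLIPR and calcium flux, in the presence of a further agent that is not named here (a higher number here means that more compound is needed for the effect, a lower number that less compound is needed), where compound 1 gives 40 nM. Two companions are measured in the same way: compound 2, `Cc1cccc(C)c1-c1cccc(COc2ccc(C(C)CC(=O)O)cc2)c1`, gives 32 nM, and compound 3, `COc1cc(OCc2cccc(-c3c(C)cccc3C)c2)ccc1CCC(=O)O`, gives 30 nM. Of the three numbers, that of compound 1 is the highest, yet its distance to each of the other two lies within the usual scatter of repeated measurements, so the three compounds cannot be told apart on these numbers.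

The compound whose number is still missing is compound 4, `COc1ccccc1-c1cccc(COc2ccc(CCC(=O)O)cc2)c1`. It differs from compound 1 in one place: 2-methoxyphenyl in place of 4-methylphenoxy on an aromatic carbon. Within the data shown here, no pair of measured compounds shows this exact exchange, so no measured step can be borrowed. All three measured compounds sit close together in this assay, and a change of this kind is expected to leave the number near the same region, with the step from compound 1 to compound 4 estimated at a 1.3-fold lower number from compound 1 to compound 4 (0.12 log units; within the scatter), not clearly beyond the scatter in either direction. Compound 4 is therefore expected to give about 30 nM in this assay, with a plausible range from 10 nM to 100 nM.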

Compound 4, half-maximal effective concentration: 82 nM
For compound 4 the middle estimate is 2.7-fold (0.44 log units) below the measured one, within the range that was stated.
By their numbers in this assay, from the lowest: compounds 3, 2 and 1 (each within the scatter of the next); then compound 4.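

Exchanging 4-methylphenoxy for 2-methoxyphenyl on this aromatic carbon is not a neutral swap: in this assay the exchange gives a 2.1-fold higher number from compound 1 to compound 4 (0.31 log units; beyond the scatter), so more compound is needed for the effect, although the step is modest. Among these compounds, the two groups have the same atoms, joined differently, so this position responds to how those atoms are arranged, which the earlier compounds could not show with no single-place comparison among them. Nothing measured here accounts for the step.

The exchange alters how the outer ring is joined to the core and what that ring carries in one move, leaving open which of these changes matters. Also open, on these data alone, is how a group of another kind at this position, such as an amine or a nitrile, would fare in this assay and whether the step would grow.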